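This account rests on a few compounds, and the source may have more. Where it says the series, first, only, none or still open, it means among the compounds named here.

Going by the values given here, only two compounds have numbers so far in a functional assay on HT-29 cells (Homo sapiens) for inhibition, read by sulforhodamine B assay, with a stated time of 48 h; a higher number here means a weaker inhibitor of growth, a lower number a stronger inhibitor of growth. Compound 1 (`c1cc(C2CCCCC2)ccc1NC1=NCCO1`) gives 12800 nM, the higher of the two numbers, which makes it the weaker growth inhibitor of the pair. Compound 2 (`c1cc(NC2=NCCO2)cc(OC2CCCCC2)c1`) gives 4400 nM, and the gap between the two values lies beyond the usual scatter. Two values do not establish a trend.

Compound 3 (`Ic1ccc(NC2=NCCO2)cc1`) has not yet been measured. It keeps the core of compound 1 and carries iodo in place of cyclohexyl on an aromatic carbon. Among the compounds with values here, no measured pair shows this exchange, so the data give no direct guide to its size or direction. The working expectation is therefore anchored on compound 1 at 12800 nM, with no shift beyond the scatter expected and a wide margin on either side. The estimated step is a 1.2-fold higher number from compound 1 to compound 3 (0.07 log units; within the scatter). For compound 3 the expected value is 15000 nM, with an estimated range of 5000 nM to 45000 nM.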

Compound 3, concentration for 50% growth inhibition: 1300 nM
The estimate for compound 3 lay 12-fold (1.06 log units) above the measured number; the whole stated range lies above it.
By their numbers in this assay, from the lowest: compound 3; then compound 2; then compound 1.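

Going by these compounds alone, on the aromatic carbon that carries cyclohexyl in compound 1, the substituent clearly matters in this assay: iodo in place of cyclohexyl gives a 9.8-fold lower number from compound 1 to compound 3 (0.99 log units; beyond the scatter), the first single-place change that can be read. On this pair, cyclohexyl is not required at this position for growth inhibition, since iodo, which has no ring, goes with the lower number, and neither group has hydrogen-bond donors or acceptors. No measurement at hand explains the step, and whether it follows from losing the ring or from the presence of iodo remains unassigned.

With only one replacement shown at this position, it remains open whether the lower number belongs to iodo specifically or would also appear with bromo, chloro, methyl, methoxy, an amine or a carboxylic acid in the same place. On these data alone, the core of compound 1 stays fixed across this pair, so the effect of changing that core while keeping iodo also remains open.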